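The source may hold more compounds than are shown below. What is called first, only, known or untested is meant among the compounds shown, and "the series" means these compounds.

Measured so far:
- compound 1 `O=C(NC1CCCCC1)N1CCN(c2nc(-c3ccc4ccccc4n3)no2)CC1`: 189 mL.min-1.g-1
- compound 2 `O=C(Nc1ccccc1Cl)N1CCC(c2nc(-c3ccc4ccccc4n3)no2)CC1`: > 200 mL.min-1.g-1
- compound 3 `Cn1c(-c2noc(C3CCN(C(=O)NC4CCCCC4)CC3)n2)nc2ccccc21`: 192 mL.min-1.g-1

In an in vitro ADME assay on microsomes from liver (Rattus norvegicus) for metabolic stability (on this read-out lower numbers stand for slow clearance and higher numbers for fast clearance), compound 1 at 189 mL.min-1.g-1 and compound 3 at 192 mL.min-1.g-1 lie within the scatter of each other. Compound 2 gives only a limit, > 200 mL.min-1.g-1, and not a number.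

Compound 4 `Cn1c(-c2noc(N3CCN(C(=O)NC4CCCCC4)CC3)n2)nc2ccccc21` keeps the core of compound 1 and carries 1-methyl-1H-benzimidazol-2-yl in place of quinolin-2-yl on an aromatic carbon. For the measured compounds named here, no measured pair isolates this change. Compound 3, which bears the same 1-methyl-1H-benzimidazol-2-yl, stands at 192 mL.min-1.g-1, so no step beyond the scatter is expected in this assay. The expected step is a 1.1-fold lower number from compound 1 to compound 4 (0.06 log units; within the scatter). For compound 4 the estimate is 165 mL.min-1.g-1, with an expected range of 85 mL.min-1.g-1 to 200 mL.min-1.g-1.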

Compound 4, intrinsic clearance in microsomes in the Rattus norvegicus assay: 119 mL.min-1.g-1
Estimate against measurement, compound 4: 1.4-fold (0.14 log units) above; measured number inside the range.
By their numbers in the Rattus norvegicus assay, from the lowest: compounds 4, 1 and 3 (each within the scatter of the next). At a limit, above all of these: compound 2.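

For the compounds shown here, this is the first pair that isolates 1-methyl-1H-benzimidazol-2-yl in place of quinolin-2-yl on this aromatic carbon: in the Rattus norvegicus assay compound 1 gives 189 mL.min-1.g-1 and compound 4 gives 119 mL.min-1.g-1 and the exchange gives a 1.6-fold lower number from compound 1 to compound 4 (0.20 log units; within the scatter) and so stays within the scatter. In a physicochemical assay for lipophilicity (on this read-out lower numbers stand for lower lipophilicity and higher numbers for higher lipophilicity), compound 1 gives 2.76 and compound 4 gives 2.57 and the same exchange gives a number 0.19 log units lower from compound 1 to compound 4 (within the scatter) in a pair that also stays within the scatter. Nothing at hand accounts for either step.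

Still open, on these data alone, is whether a smaller group at this place, such as methyl, or a phenyl carrying a carboxylic acid or an amine, would bring a step beyond the scatter in the Rattus norvegicus assay.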